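Swapping chloro for trifluoromethyl on two related aryl cores

This account rests on a few compounds, and the source may have more. Where it says the series, first, only, none or still open, it means among the compounds named here.

In an ADME assay on Vero cells (Chlorocebus sabaeus) for cytotoxicity, read by MTT assay, with a stated time of 72 h (on this read-out higher numbers stand for weaker inhibition and lower numbers for stronger inhibition), the three measured compounds give the following numbers:

Compound 1, `O=C(CCN1CCN(c2ccc(Cl)cc2)CC1)c1ccc(O)cc1`, gives 104000 nM.
Compound 2, `O=C(CCN1CCN(c2ccc(C(F)(F)F)cc2)CC1)c1ccc(O)cc1`, gives 107000 nM.
Compound 3, `COc1ccc(C(=O)CCNc2ccc(Cl)cc2)cc1`, gives 146000 nM.

Compound 1 and compound 2 share a core and differ only by trifluoromethyl in place of chloro on an aromatic carbon. That change gave a 1.0-fold higher number from compound 1 to compound 2 (0.01 log units; within the scatter), so the two numbers are not distinguishable in this assay. Compound 3 carries a different core; the difference between the two cores is not broken down here. Its value sits within the scatter of both compound 1 and compound 2, so no order among the three can be read from these numbers.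

Compound 4, `COc1ccc(C(=O)CCNc2ccc(C(F)(F)F)cc2)cc1`, has not yet been measured. It differs from compound 3 by trifluoromethyl in place of chloro on an aromatic carbon, the same change that turned compound 1 into compound 2. Because that earlier step was a 1.0-fold higher number from compound 1 to compound 2 (0.01 log units; within the scatter), the step from compound 3 to compound 4 is also expected to be small, about a 1.0-fold higher number from compound 3 to compound 4 (0.01 log units; within the scatter). Compound 4 is therefore estimated at 150000 nM, with a likely range from 80000 nM to 280000 nM.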

Compound 4, half-maximal inhibitory concentration: 32600 nM
For compound 4 the middle estimate is 4.6-fold (0.66 log units) above the measured one, and the stated range ends above it.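

In this assay, putting trifluoromethyl in place of chloro gave a 4.5-fold lower number from compound 3 to compound 4 (0.65 log units; beyond the scatter) and counts as a modest step. The same swap did not give the same result on the two cores, so the size of the step on one core cannot simply be carried over to the other: the same change on two cores in this assay, a 1.0-fold higher number (0.01 log units; within the scatter) from compound 1 to compound 2 and a 4.5-fold lower number (0.65 log units; beyond the scatter) from compound 3 to compound 4, 4.6-fold (0.66 log units) apart, beyond the scatter of two such steps. This shows that, for these two pairs, the outcome of the change depends on the core that carries it, but it does not show which part of the cores is responsible, and two pairs give no rule for any other core in the series.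

The compounds shown leave open whether other groups in the same place on the core of compound 3, such as a nitrile or a methyl group, would also separate from chloro. They also leave open whether the step would survive a longer chain in that core, which would help tell what sets the two cores apart.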